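This account rests on a few compounds, and the source may have more. Where it says the series, first, only, none or still open, it means among the compounds named here.

Measured so far:
compound 1 `CC(C)[C@H](NC(=O)COc1cccc2ccccc12)C(=O)N[C@@H](CC(=O)O)C(=O)CSc1nc(-c2ccccc2)c(-c2ccccc2)o1` in a functional assay on Jurkat cells (Homo sapiens) for inhibition; a lower number here means a stronger inhibitor, a higher number a weaker inhibitor: > 200000 nM
compound 2 `CC(C)[C@H](NC(=O)COc1cccc2ccccc12)C(=O)N[C@@H](CC(=O)O)C(=O)CSc1nc[nH]n1` in this assay: > 200000 nM

Compound 1 gives only a limit of the assay in this assay, not a number; the reading for compound 1 is > 200000 nM. Compound 2 likewise gives only a limit in this assay, the reading for compound 2 being > 200000 nM. On the numbers shown, compound 2 therefore stands at the limit, where both readings sit (the limit of > 200000 nM in this assay, at which 2 of the 2 values shown sit). Between the two measured compounds no step can be sized, since neither yields a number.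

Compound 3 `Cc1cc(OCC(=O)[C@H](CC(=O)O)NC(=O)[C@@H](NC(=O)COc2cccc3ccccc23)C(C)C)nc(C)n1` has not yet been measured in this assay. It differs from compound 2 in one place: (2,6-dimethylpyrimidin-4-yl)oxy in place of (1H-1,2,4-triazol-3-yl)sulfanyl on a saturated chain carbon bound to a carbonyl carbon. Going by the values given here, nothing among the measured compounds shows how this change would move the reading. The expected step is a number no higher from compound 2 to compound 3 (the limit leaves the size open), that is, no shift beyond the scatter is expected, with compound 3 most likely again at the limit. Compound 3 is estimated to give 200000 nM in this assay, within a range of 50000 nM to 1000000 nM.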

Compound 3, half-maximal inhibitory concentration: > 200000 nM
Compound 3: no number, only a limit; the forecaster's own chance of this, stated with the estimate: 75%; the middle value lies on the limit itself.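

No step can be read between compound 2 and compound 3 in this assay, as both readings are limits and not numbers: the limit of > 200000 nM in this assay, at which 3 of the 3 values shown sit.

The compounds shown leave open whether any group on the saturated chain carbon bound to a carbonyl carbon can bring a reading inside the range of this assay.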